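A few compounds are considered here, and "the series" means these few. Any claim that something is new, unique, unknown or untested is made for them only; others in the source may bear on it.

Of the compounds shown here, three sharing one core have been measured in a functional assay on HCT-116 cells (Homo sapiens) for inhibition, read by MTT assay; a lower number here means a stronger inhibitor, a higher number a weaker inhibitor. Compound 1 `COc1ccc(C(Nc2ccccc2)n2c(=O)ccc3cc(O)ccc32)cc1` gives 53700 nM. Compound 2 `COc1ccc(C(Nc2ccc(Cl)cc2)n2c(=O)ccc3cc(O)ccc32)cc1` gives 20400 nM in this assay, and compound 3 `COc1ccc(C(Nc2ccc(Br)cc2)n2c(=O)ccc3cc(O)ccc32)cc1` gives 19600 nM. Among these three numbers compound 2 stands second highest: the step of a 2.6-fold lower number from compound 1 to compound 2 (0.42 log units; beyond the scatter) separates it from compound 1, whereas a 1.0-fold lower number from compound 2 to compound 3 (0.02 log units; within the scatter) leaves it indistinguishable from compound 3, and a 2.7-fold lower number from compound 1 to compound 3 (0.44 log units; beyond the scatter) matches the first step. Compound 4 `COc1ccc(NC(c2ccc(OC)cc2)n2c(=O)ccc3cc(O)ccc32)cc1` differs from compound 2 by methoxy in place of chloro on an aromatic carbon. Among the compounds with values here, no measured step exchanges chloro for anything but bromo; the steps that bear on this change are the modest gain on adding chloro, a 2.6-fold lower number from compound 1 to compound 2 (0.42 log units; beyond the scatter), and the flat exchange for bromo, a 1.0-fold lower number from compound 2 to compound 3 (0.02 log units; within the scatter). With no halogen remaining in compound 4, its number is expected to settle between the unsubstituted and the halogenated cases, a small rise in this assay, so the expected step is a 1.7-fold higher number from compound 2 to compound 4 (0.23 log units; within the scatter). Compound 4 is therefore estimated at 35000 nM, within 12000 nM to 100000 nM.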

Compound 4, half-maximal inhibitory concentration: 73300 nM
Compound 4: middle estimate off by 2.1-fold (0.32 log units), on the low side; the measured number falls inside the stated range.
By their numbers in this assay, from the lowest: compounds 3 and 2 (each within the scatter of the next); then compounds 1 and 4 (each within the scatter of the next).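

In this assay the lower number reached with chloro and bromo at this position does not extend to methoxy: the exchange for chloro gives a 3.6-fold higher number from compound 2 to compound 4 (0.56 log units; beyond the scatter), and the exchange for bromo gives a 3.7-fold higher number from compound 3 to compound 4 (0.57 log units; beyond the scatter). Against the unsubstituted compound, methoxy gives a 1.4-fold higher number from compound 1 to compound 4 (0.14 log units; within the scatter), so compound 4 cannot be told apart from compound 1, and having a group at this position does not in itself lower the number. Nothing available accounts for the difference between the halogens and methoxy. The compounds shown leave open whether another group here, such as fluoro, methyl or an amine, would track the halogens or methoxy. They also leave open whether the same order would hold with a group other than methoxy on the second aromatic ring of the shared core.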